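The compounds below may be only part of what the source reports. "The series", "measured", "known", "first", "only" and "open" are said of these compounds alone.

Measured compounds:
compound 1, `CCCCNc1nc(N)nc2cccnc12`: 1900 nM
compound 2, `CCCC(C)Nc1nc(N)nc2cccnc12`: 3100 nM
compound 3, `CCCCC[C@](C)(CO)Nc1nc(N)nc2cccnc12`: 580 nM

All three were run in an assay on tissue (PBMC cells) for agonist activity at Toll-like receptor 8 (Homo sapiens), with a stated time of 24 h; on this read-out higher numbers stand for an effect only at larger amounts of compound and lower numbers for an effect already at smaller amounts. Compound 3 gives the lowest number of the three, its gap to compound 1 and to compound 2 lying beyond the scatter in each case. The difference between the core of compound 3 and the core of compound 1 is not broken down here. Within the series the change methyl in place of hydrogen on a saturated chain carbon bound to a nitrogen on an aromatic ring and a saturated chain carbon gave a 1.6-fold higher number from compound 1 to compound 2 (0.21 log units; within the scatter).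

Compound 4, `CCCCCC[C@](C)(CO)Nc1nc(N)nc2cccnc12`, has not been measured in this assay. It differs from compound 3 by methyl in place of hydrogen on a saturated chain carbon, six bonds along the chain from a nitrogen on an aromatic ring. This is the same kind of change as from compound 1 to compound 2, but around a different place: there the carbon was bound to a nitrogen on an aromatic ring and a saturated chain carbon, here it lies six bonds along the chain from a nitrogen on an aromatic ring. Within the data shown here, compound 4 is expected to show a 1.2-fold lower number from compound 3 to compound 4 (0.06 log units; within the scatter) because the only comparable step a 1.6-fold higher number from compound 1 to compound 2 (0.21 log units; within the scatter) stayed within the scatter. Compound 4 is estimated at 500 nM in this assay, between 200 nM and 1400 nM.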

Compound 4, half-maximal effective concentration in the Toll-like receptor 8 assay: 10000 nM
Beside the measured number, compound 4's estimate is 20-fold (1.30 log units) below it; measured number outside the range, above it.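

In the Toll-like receptor 8 assay the added methyl gives a 17-fold higher number from compound 3 to compound 4 (1.24 log units; beyond the scatter), so its effect does not carry over in size between these two cores: the same change on two cores in the Toll-like receptor 8 assay, a 1.6-fold higher number (0.21 log units; within the scatter) from compound 1 to compound 2 and a 17-fold higher number (1.24 log units; beyond the scatter) from compound 3 to compound 4, 11-fold (1.02 log units) apart, beyond the scatter of two such steps The rise in compound 4's number comes with a higher reading in a physicochemical assay for lipophilicity, read by HPLC, with a stated time of 30 min (on this read-out higher numbers stand for higher lipophilicity and lower numbers for lower lipophilicity), which fits a link between the two read-outs but does not establish one: the measured distribution coefficient of compound 3, 1.8, and of compound 4, 2.5, a number 0.70 log units higher (beyond the scatter) In the physicochemical assay compound 3 gives 1.8 and compound 4 gives 2.5. Only one pair per core is shown, and the methyl sits at a different place in each pair, so these data cannot separate the influence of the core from that of the place.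

Still open, as far as these compounds go, is how a longer chain or an amine at the same place would read in the Toll-like receptor 8 assay. Also open, from the compounds shown here alone, is whether the physicochemical assay would follow the same trend for those groups.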